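Ethyl replacing dimethylamino on the shared core of compound 1

The source may hold more compounds than are shown below. What is called first, only, known or untested is meant among the compounds shown, and "the series" means these compounds.

Compound 1 `CN(C)c1ccc(N2C(=O)NC3(CSC4=C3C(=O)c3ncccc3C4=O)C2=O)cc1` gives 1 nM in a functional assay on CCRF-SB cells (Homo sapiens) for antiproliferative activity, read by MTT assay, with a stated time of 96 h; a higher number here means a weaker inhibitor, a lower number a stronger inhibitor. Compound 2 `CCCc1ccc(N2C(=O)NC3(CSC4=C3C(=O)c3ncccc3C4=O)C2=O)cc1` gives 2 nM, and a 2.0-fold higher number from compound 1 to compound 2 (0.30 log units; within the scatter). Compound 3 `CCN(CC)c1ccc(N2C(=O)NC3(CSC4=C3C(=O)c3ncccc3C4=O)C2=O)cc1` gives 9 nM, and a 9.0-fold higher number from compound 1 to compound 3 (0.95 log units; beyond the scatter). Compound 1 thus sits with compound 2 within the scatter, while compound 3 stands apart. Compound 4 `CCc1ccc(N2C(=O)NC3(CSC4=C3C(=O)c3ncccc3C4=O)C2=O)cc1` differs from compound 1 as follows: ethyl in place of dimethylamino on an aromatic carbon. Of the measured steps, the change to propyl, a 2.0-fold higher number from compound 1 to compound 2 (0.30 log units; within the scatter), is the closest analogue, and the change to diethylamino, a 9.0-fold higher number from compound 1 to compound 3 (0.95 log units; beyond the scatter), shows a modest loss. On this basis a small or no step beyond the scatter is expected, so compound 4 is estimated at 2 nM, between 0.7 nM and 6 nM, meaning a 2.0-fold higher number from compound 1 to compound 4 (0.30 log units; within the scatter).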

Compound 4, half-maximal inhibitory concentration: 10 nM
For compound 4 the middle estimate is 5.0-fold (0.70 log units) below the measured one; measured number above the stated range.
By their numbers in this assay, from the lowest: compounds 1 and 2 (each within the scatter of the next); then compounds 3 and 4 (each within the scatter of the next).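

Replacing dimethylamino with ethyl in this assay is not the small change that propyl was: it gives a 10-fold higher number from compound 1 to compound 4 (1.00 log units; beyond the scatter). One chain carbon counts at this position, as hydrogen in place of the end methyl of propyl gives a 5.0-fold higher number from compound 2 to compound 4 (0.70 log units; beyond the scatter). Ethyl also falls level with diethylamino, at a 1.1-fold higher number from compound 3 to compound 4 (0.05 log units; within the scatter), so the two alkyl chains shown do not behave alike, and a nitrogen-bearing group can sit on either side of this gap.

Nothing available explains this sensitivity to one carbon. As far as these compounds go, whether a butyl chain, a methyl group or a pyrrolidine ring at this place would follow propyl or ethyl remains open.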